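The source may hold more compounds than are shown below. What is called first, only, known or untested is meant among the compounds shown, and "the series" means these compounds.

Measured compounds:
- compound 1 `CNc1ncnc2c1c(-c1ccccc1)cn2[C@@H]1O[C@H](CO)[C@@H](O)[C@H]1O`; in a functional assay on HCT-116 cells (Homo sapiens), read by MTT assay, with a stated time of 72 h (on this read-out higher numbers stand for weaker inhibition and lower numbers for stronger inhibition), compound 1 gives only a limit of the assay, > 20000 nM.
- compound 2 `O=c1[nH]cnc2c1c(-c1cc3ccccc3o1)cn2[C@@H]1O[C@H](CO)[C@@H](O)[C@H]1O`; in this assay compound 2 gives only a limit, > 20000 nM.
- compound 3 `CNc1ncnc2c1c(-c1cc3ccccc3o1)cn2[C@@H]1O[C@H](CO)[C@@H](O)[C@H]1O`; in this assay compound 3 gives only a limit, > 20000 nM.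

All three values sit at the same point, (the limit of > 20000 nM in this assay, at which 3 of the 3 values shown sit), so none of them is a number and no order among the three compounds can be read.

Compound 3 and compound 1 differ by one change, (phenyl in place of 1-benzofuran-2-yl on an aromatic carbon). The step that the two limits leave unreadable from compound 3 to compound 1 cannot be sized, since both ends are limits. The difference between the core of compound 2 and the core of compound 3 is not broken down here.

Compound 4 `O=c1[nH]cnc2c1c(-c1ccccc1)cn2[C@@H]1O[C@H](CO)[C@@H](O)[C@H]1O` is not yet measured in this assay. It differs from compound 2 by phenyl in place of 1-benzofuran-2-yl on an aromatic carbon, which is the same change as that from compound 3 to compound 1, made at the same place. Because compound 3 and compound 1 both sit at the limit of > 20000 nM in this assay, at which 3 of the 3 values shown sit, and compound 2 does as well, the step that the limit leaves unreadable from compound 2 to compound 4 is expected to be unreadable in the same way, with compound 4 most likely also returning only a limit. For compound 4 the estimate in this assay is 30000 nM, with a range from 10000 nM to 100000 nM, and the expectation rests on the three limits of compound 1, compound 2 and compound 3 rather than on any numeric step.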

Compound 4, half-maximal inhibitory concentration: > 100000 nM
Compound 4: no number, only a limit; the forecaster's own chance of this, stated with the estimate: 85%; middle value at least 3.3-fold (0.52 log units) away from the limit.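

Compound 4 gives > 100000 nM in this assay as a limit and not a number. Compound 2 also returns only a limit, so no new step can be read between compound 2 and compound 4. The compounds shown leave open whether either the aromatic group or the difference between the two cores has any effect on the read-out, as all four values are limits.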